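This account rests on a few compounds, and the source may have more. Where it says the series, first, only, none or still open, it means among the compounds named here.

Series notes. Compound 1 `CS(=O)(=O)c1ccc(C(=O)NCCC(=O)N2CCCc3ccccc32)cc1[N+](=O)[O-]` carries the shared core with a 1,2,3,4-tetrahydroquinolin-1-yl group on the carbonyl carbon. In an assay on isolated protein for inhibition of thyroid hormone receptor beta (Homo sapiens), read by fluorescence polarization (on this read-out higher numbers stand for weaker inhibition and lower numbers for stronger inhibition), compound 1 gives > 60000 nM, which is a limit of the assay and not a number. Compound 2 `CC1Cc2ccccc2N1C(=O)C1CCN(C(=O)c2ccc(S(C)(=O)=O)c([N+](=O)[O-])c2)CC1` is the second measured member. In this assay compound 2 gives > 60000 nM, again a limit and not a number. Among the measured compounds shown here, both readings sit at the same point, (the limit of > 60000 nM in this assay, at which 2 of the 2 values shown sit), so no step between measured compounds can be drawn and compound 1 stands on a limit alone, with no ranking against compound 2 possible. Compound 3 `CC1CCN(C(=O)CCNC(=O)c2ccc(S(C)(=O)=O)c([N+](=O)[O-])c2)CC1` is not yet measured. It differs from compound 1 by 4-methylpiperidin-1-yl in place of 1,2,3,4-tetrahydroquinolin-1-yl on a carbonyl carbon, the smaller saturated ring entering at the place stated. For the measured compounds named here, with no measured step to lean on, no movement beyond the scatter is expected in this assay, and the direction stays open. The expected result for compound 3 is 80000 nM, within 30000 nM to 300000 nM, most likely again reported as a limit. The implied expectation is a step that the limit leaves unreadable from compound 1 to compound 3.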

Compound 3, half-maximal inhibitory concentration: > 60000 nM
Compound 3: no number, only a limit (the forecaster's own chance of this, stated with the estimate: 85%); the middle value lies beyond the limit too.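

No step can be read from compound 1 to compound 3, as both stand only on a limit in this assay and no number exists for either: the limit of > 60000 nM in this assay, at which 3 of the 3 values shown sit.
The compounds shown leave open how 4-methylpiperidin-1-yl and 1,2,3,4-tetrahydroquinolin-1-yl rank, and whether any member gives a measurable inhibition.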